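The source may report more compounds than this note shows. Statements on the series, on what has been measured and on what is new or still open speak of the compounds shown alone.

Compound 1 `COc1ccc(C)cc1N1C(=O)CSC1c1cccc(C(=O)NCCCCc2ccccc2)c1`: 300 nM
Compound 2 `COc1ccccc1N1C(=O)CSC1c1cccc(C(=O)NCCCCc2ccc(Cl)cc2)c1`: 78.6 nM
Compound 3 `COc1ccccc1N1C(=O)CSC1C(=O)NCCCCc1ccccc1`: > 1000 nM

In a functional assay on HOS-TE85 cells (Homo sapiens) for inhibition, read by CCK-8 assay, with a stated time of 72 h (a lower number here means a stronger inhibitor, a higher number a weaker inhibitor), compound 1 stands at the higher of the two numbers shown; compound 2 sits at a lower number, and that gap is beyond the usual scatter. For compound 3 the result is only a limit of the assay, not a number: the limit of > 1000 nM in this assay, at which 1 of the 3 values shown sits.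

Compound 4 `O=C(NCCCCc1ccccc1)c1cccc(C2SCC(=O)N2c2cccc(-c3c[nH]nn3)c2)c1` has not yet been measured in this assay. It differs from compound 1 in one place: a group of 11 heavy atoms (8 carbon, 3 nitrogen; one five-membered aromatic ring with 3 hetero atoms, one six-membered aromatic ring of carbon only) in place of a group of 9 heavy atoms (8 carbon, 1 oxygen; one six-membered aromatic ring of carbon only), on an amide-type nitrogen in a ring. Among the measured compounds shown here, no step between measured compounds matches this change, so its size rests on no direct evidence. The expected step is a 1.3-fold higher number from compound 1 to compound 4 (0.12 log units; within the scatter), a modest move toward a higher number that may well stay within the scatter. Compound 4 is therefore estimated to give 400 nM in this assay, with a likely range from 100 nM to 1500 nM.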

Compound 4, half-maximal inhibitory concentration: 110 nM
Compound 4: the middle estimate sits 3.6-fold (0.56 log units) above what was measured, and the stated range covers the measured number.
By their numbers in this assay, from the lowest: compounds 2 and 4 (each within the scatter of the next); then compound 1. At a limit, above all of these: compound 3.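

In this assay, the group on the amide-type nitrogen in the ring tolerates a large change: replacing the 2-methoxy-5-methylphenyl with a six-membered aromatic ring of carbon only that carries a five-membered aromatic ring with 3 hetero atoms gives a 2.7-fold lower number from compound 1 to compound 4 (0.44 log units; beyond the scatter). Compound 4 is also the first compound shown without a methoxy group on this ring, so a methoxy group is not required here for activity on this scale. Nothing measured here accounts for the size or direction of this step.

From the compounds shown here alone, how a plain phenyl, a tetrazole or a carboxylic acid would read at this position remains open, so the part of the new group that carries the step is unknown. Going by these compounds, it is also open whether the step would hold on a compound with the 4-chlorophenyl end of the chain found in compound 2.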